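A few compounds are considered here, and "the series" means these few. Any claim that something is new, unique, unknown or untested is made for them only; others in the source may bear on it.

Compound 1 `O=c1ccoc2cc(OCc3cn(Cc4ccc(Cl)cc4Cl)nn3)ccc12` has been run in a functional assay on SGC-7901 cells (Homo sapiens) for cytotoxicity, read by MTT assay, with a stated time of 48 h; on this read-out lower numbers stand for stronger inhibition and higher numbers for weaker inhibition. In this assay compound 1 returns only a limit, > 100000 nM. Compound 2 `CC(C)(C)c1ccc(Cn2cc(COc3ccc4c(=O)ccoc4c3)nn2)cc1` likewise returns a limit in this assay, > 100000 nM. Compound 3 `C#CCOc1ccc2c(=O)ccoc2c1` also reaches only a limit in this assay, > 100000 nM. Compound 1 therefore stands with the other two at the limit of > 100000 nM in this assay, at which 3 of the 3 values shown sit, and no ordering among the three can be drawn from the numbers. Compound 4 `O=c1ccoc2cc(OCc3cn(Cc4ccccc4F)nn3)ccc12` is not yet measured; it differs from compound 1 by 2-fluorophenyl in place of 2,4-dichlorophenyl on a saturated chain carbon bound to an aromatic nitrogen. Going by the values given here, no measured step exists to point a direction. The expected step is a step that the limit leaves unreadable from compound 1 to compound 4, none beyond the scatter. For compound 4 the estimate is 150000 nM, with a range from 100000 nM to 300000 nM, and a limit rather than a number is the likelier outcome.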

Compound 4, half-maximal inhibitory concentration: > 100000 nM
Compound 4: only a limit was reported (the forecaster's own chance of this, stated with the estimate: 85%); the middle value lies beyond the limit too.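

In this assay, going by these compounds alone, compound 1 and compound 4 both give only limits, so no step between them can be read. The compounds shown leave open which structural change, if any, would give a number in this assay rather than a limit.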